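A few compounds are considered here, and "the series" means these few. Any claim that something is new, unique, unknown or untested is made for them only; others in the source may bear on it.

Working notes on the series in an assay on mitochondria from L6 cells (Rattus norvegicus) for activation, with a stated time of 90 min; on this read-out lower numbers stand for an effect already at smaller amounts and higher numbers for an effect only at larger amounts of compound. Compound 1 `CCc1ccc(Nc2nc3nonc3nc2O)cc1` gives 10700 nM in this assay and holds the highest of the two numbers recorded so far. Its nearest neighbour is compound 2 `CCc1ccc(Nc2nc3nonc3nc2O)c(F)c1`, which gives 6700 nM in this assay; the step of a 1.6-fold lower number from compound 1 to compound 2 (0.20 log units; within the scatter) comes from fluoro in place of hydrogen on an aromatic carbon and stays within the scatter. Compound 3 `Oc1nc2nonc2nc1Nc1ccc(C(F)(F)F)cc1` has not been measured in this assay. It differs from compound 1 as follows: trifluoromethyl in place of ethyl on an aromatic carbon. Within the data shown here, no measured step swaps one chain for a trifluoromethyl; the single step at hand concerns a different change and was within the scatter, so it offers no direction for this one. The shared core is unchanged throughout. With nothing beyond the scatter among the recorded steps, no step beyond the scatter is expected here either. Compound 3 is therefore expected to give about 8000 nM in this assay, with a range from 3000 nM to 25000 nM. Among the measured compounds shown here, this estimate means a step of a 1.3-fold lower number from compound 1 to compound 3 (0.13 log units; within the scatter), expected to remain within the scatter; the range is kept wide, as no measured step covers this kind of change.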

Compound 3, half-maximal effective concentration: 10400 nM
Compound 3: the middle estimate sits 1.3-fold (0.11 log units) below what was measured; the range from low to high includes it.
By their numbers in this assay, from the lowest: compounds 2, 3 and 1 (each within the scatter of the next).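

In this assay, trifluoromethyl in place of ethyl on an aromatic carbon, para to a large group, gives a 1.0-fold lower number from compound 1 to compound 3 (0.01 log units; within the scatter), so compound 1 and compound 3 cannot be told apart on this read-out. Among these compounds, this is the first measured swap at this place, and it shows that ethyl, with 2 heavy atoms, and trifluoromethyl, with 4 heavy atoms including 3 fluorine, give no separation here, whereas the earlier step concerned only fluoro in place of hydrogen on an aromatic carbon. No supporting measurement is available to explain why these two groups read alike in this assay.

On these data alone, whether an amine, a carboxylic acid or a chain longer than ethyl at this same place would give a step beyond the scatter remains open. With no step in the series yet beyond the scatter, the compounds shown do not establish which changes, at this place or elsewhere on the shared core, this read-out responds to.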